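A few compounds are considered here, and "the series" means these few. Any claim that something is new, unique, unknown or untested is made for them only; others in the source may bear on it.

Of the compounds shown here, three have so far been measured in a functional assay on K562 cells (Homo sapiens) for inhibition, read by sulforhodamine B assay, with a stated time of 48 h; a lower number here means a stronger inhibitor of growth, a higher number a weaker inhibitor of growth. Compound 1 `COc1cc(C)cc(-c2c(-c3ccnc(-c4ccc(C(C)=O)cc4)c3)cnn2CC#N)c1` gives 795 nM, the second highest of the three numbers. Compound 3 `COc1cc(C)cc(-c2nn(CC#N)cc2-c2ccnc(-c3ccc(N(C)C)cc3)c2)c1` gives 161 nM, a lower number that lies beyond the scatter, and compound 2 `Cc1cc(O)cc(-c2nn(CC#N)cc2-c2ccnc(-c3ccc(Oc4ccccc4)cc3)c2)c1` gives 4870 nM, a higher number that also lies beyond the scatter. Compound 4 `COc1cc(C)cc(-c2c(-c3ccnc(-c4ccc(N(C)C)cc4)c3)cnn2CC#N)c1` has not been measured. It differs from compound 1 in one place: dimethylamino in place of acetyl on an aromatic carbon. Among the measured compounds shown here, no measured pair shows this exact change, so the size of the step is uncertain. Compound 3 carries a 4-(dimethylamino)phenyl and gives 161 nM, which points toward a lower number for compound 4. A moderate decrease is expected, a 3.2-fold lower number from compound 1 to compound 4 (0.50 log units; beyond the scatter). Compound 4 is expected to give about 250 nM, with a range from 80 nM to 800 nM.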

Compound 4, concentration for 50% growth inhibition: 58.4 nM
Beside the measured number, compound 4's estimate is 4.3-fold (0.63 log units) above it; the whole stated range lies above it.
By their numbers in this assay, from the lowest: compound 4; then compound 3; then compound 1; then compound 2.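

In this assay, among the compounds shown here, replacing 4-acetylphenyl with 4-(dimethylamino)phenyl gives a 14-fold lower number from compound 1 to compound 4 (1.13 log units; beyond the scatter), the first step read between compounds that differ in one place, and it shows that the number is sensitive to the group at this position. The two groups match in heavy atoms, hydrogen-bond acceptors and donors, so those counts do not separate them. No measured evidence accounts for the size of this step. From the compounds shown here alone, whether a methylamino group, a morpholine ring or a methoxy group would give a similar number remains open. So does whether the step would recur with a hydroxyl in place of the methoxy group.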